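A few compounds are considered here, and "the series" means these few. Any claim that something is new, unique, unknown or untested is made for them only; others in the source may bear on it.

The measured compounds:

Compound 1, `CCO[C@H]1C[C@@H](c2coc3ccc(Br)cc3c2=O)N(c2ccccc2)O1`: in a functional assay on THP-1 cells (Homo sapiens) for inhibition, read by sulforhodamine B assay, with a stated time of 48 h (a higher number here means a weaker inhibitor, a lower number a stronger inhibitor), compound 1 gives > 60000 nM, a limit of the assay rather than a number.
Compound 2, `N#C[C@H]1C[C@@H](c2coc3ccc(Cl)cc3c2=O)N(c2ccccc2)O1`: in this assay compound 2 gives 35000 nM.
Compound 3, `COC(=O)[C@@]1(C)C[C@@H](c2coc3ccc(C)cc3c2=O)N(c2ccccc2)O1`: in this assay compound 3 gives 7300 nM.

Compound 1 stands at the edge of what this assay reports, (the limit of > 60000 nM in this assay, at which 1 of the 3 values shown sits), so only a limit and no number is known for it. Compound 2 and compound 3 each give a number, and of the two, compound 3 gives the lower one; both differ from compound 1 in more than one place, so the values show only that much.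

Compound 4, `CCO[C@H]1C[C@@H](c2coc3ccc(C)cc3c2=O)N(c2ccccc2)O1`, differs from compound 1 by methyl in place of bromo on an aromatic carbon. Within the data shown here, no pair of measured compounds differs in that single place, so the size of the step has to be estimated. Compound 3 also carries a methyl on its aromatic ring and gives the lowest number shown, but it differs from compound 1 elsewhere as well. The step expected from this change is an at least 1.5-fold lower number from compound 1 to compound 4 (0.17 log units; that floor lies within the scatter), a modest move toward stronger inhibition that may not exceed the scatter. Compound 4 is therefore estimated at 40000 nM, within 10000 nM to 150000 nM, and a limit rather than a number remains a real possibility.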

Compound 4, half-maximal inhibitory concentration: 41000 nM
Compound 4: middle estimate off by 1.0-fold (0.01 log units), on the low side; the range from low to high includes it.
By their numbers in this assay, from the lowest: compound 3; then compounds 2 and 4 (each within the scatter of the next). At a limit, above all of these: compound 1.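

Methyl in place of bromo on the aromatic carbon gives the first step in this set that changes a single place, and in this assay it reads as an at least 1.4-fold lower number from compound 1 to compound 4 (0.16 log units; that floor lies within the scatter). That figure is a floor and not the size of the step, so the true change could be larger, and compound 4 gives a number on the core of compound 1, where that compound reached only a limit. The step cannot be sized more closely, as its starting point is not a number: the limit of > 60000 nM in this assay, at which 1 of the 4 values shown sits.

From the compounds shown here alone, how large the step is, and whether it goes beyond the scatter, stays open. The compounds shown also leave open how an amine, a methoxy or a longer chain such as ethyl would read on this same aromatic carbon.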